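A few compounds are considered here, and "the series" means these few. Any claim that something is new, unique, unknown or untested is made for them only; others in the source may bear on it.

For the measured compounds named here, compound 1, `CCOc1cccc2cc(-c3ccccc3)c(=O)oc12`, is the one compound among the three measured whose result in an assay on CHO cells for displacement of a labelled ligand from adenosine receptor A1 (Homo sapiens), read by radioligand binding (on this read-out lower numbers stand for stronger inhibition and higher numbers for weaker inhibition), is an actual number: compound 1 gives 22100 nM. Compound 2, `CCOc1cccc2cc(-c3ccc(OC)cc3)c(=O)oc12`, carries a methoxy in place of hydrogen on an aromatic carbon. In this assay compound 2 gives only a limit of the assay, > 100000 nM. Compound 3, `CCOc1cccc2cc(-c3ccc([N+](=O)[O-])cc3)c(=O)oc12`, carries a nitro in place of hydrogen on an aromatic carbon. In this assay compound 3 also gives only a limit, > 100000 nM. Both changes therefore weaken binding: an at least 4.5-fold higher number from compound 1 to compound 2 (0.65 log units; beyond the scatter) and an at least 4.5-fold higher number from compound 1 to compound 3 (0.65 log units; beyond the scatter). The step that the two limits leave unreadable from compound 2 to compound 3 cannot be sized because of the limit of > 100000 nM in this assay, at which 2 of the 3 values shown sit.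

Compound 4, `O=c1oc2c(O)cccc2cc1-c1ccccc1`, is not yet measured. It differs from compound 1 in one place: hydrogen in place of ethyl on an oxygen on an aromatic ring. Read one bond further out, the change is ethoxy to hydroxy. Neither measured step touches this oxygen; both concern substituents on the other aromatic ring, so none of them bears directly on this change. Going by the values given here, with no step to lean on, the expectation for compound 4 is a step of a 1.0-fold lower number from compound 1 to compound 4 (0.00 log units; within the scatter), that is, none beyond the scatter. Compound 4 is therefore estimated at 22000 nM, within a range of 6000 nM to 80000 nM.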

Compound 4, inhibition constant: 4620 nM
The estimate for compound 4 lay 4.8-fold (0.68 log units) above the measured number; the measured number lies below the stated range.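

This is the first change shown at this oxygen, and in this assay it is also the first change shown that strengthens binding: replacing the ethyl with hydrogen, which turns ethoxy into hydroxy, gives a 4.8-fold lower number from compound 1 to compound 4 (0.68 log units; beyond the scatter). The ethyl is therefore not needed for binding to this receptor, and losing its two carbons brings a gain, whereas methoxy and nitro in place of hydrogen on an aromatic carbon both weakened binding, leaving compound 2 and compound 3 at limits of the assay. Nothing measured here shows why the number falls when the ethyl leaves.

The compounds shown leave open whether the gain comes from the hydroxy itself or only from the loss of the ethyl; a methyl or a propyl on this oxygen, or an amine in place of the hydroxy, would help tell these apart. Also open, going by these compounds, is whether the hydroxy keeps its gain when combined with the methoxy or the nitro, and the step between compound 2 and compound 3 cannot be read.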